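A few compounds are considered here, and "the series" means these few. Any claim that something is new, unique, unknown or untested is made for them only; others in the source may bear on it.

Measured compounds:
compound 1, `CCc1ccc(NC(=O)N[C@@H](C)c2ccccc2)cc1`, 99%
compound 2, `CC(C)c1ccc(NC(=O)N[C@@H](C)c2ccccc2)cc1`, 98%
compound 3, `CCCc1ccc(NC(=O)N[C@H](C)c2ccccc2)cc1`, 33%

In an ADME assay on the whole organism with Oryza sativa as the target, tested at 0.1 uM (on this read-out lower numbers stand for a stronger effect and higher numbers for a weaker effect at the one concentration tested), compound 3 stands lowest of the three, and so shows the strongest effect. Its nearest neighbour is compound 2, whose number lies beyond the scatter above it, and compound 1 lies a little further above again. Within the data shown here, compound 1 and compound 2 give numbers within the scatter of each other, and the only measured single-point change, a number 1 percentage points lower from compound 1 to compound 2 (within the scatter), is therefore no change at all in this read-out.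

Compound 4, `CCCc1ccc(NC(=O)N[C@@H](C)c2ccccc2)cc1`, has not been measured. Compared with compound 3, (the two compounds have the same atoms and bonds and differ only in configuration as drawn: 1 of 1 stereo elements differ; a stereocentre at a saturated chain carbon is drawn R in compound 3 and S in compound 4). Among the measured compounds shown here, no measured pair differs in configuration alone, so no step bears directly on this change. What the values do show is that compound 1 and compound 2, both drawn with the same configuration as compound 4, give high numbers, while compound 3, drawn the other way, gives a low one; yet those compounds also differ from compound 3 elsewhere, so the cause of its low number cannot be separated here. The expectation for compound 4 is therefore a rise of a number 47 percentage points higher from compound 3 to compound 4 (beyond the scatter) in this assay, but with wide uncertainty. Compound 4 is estimated at 80%, ranging from 35% to 100%.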

Compound 4, a percentage reported as activity, at one concentration (the size of the read-out at that concentration, not a potency): 97%
Compound 4: the middle estimate sits 17 percentage points below what was measured, within the range that was stated.
By their numbers in this assay, from the lowest: compound 3; then compounds 4, 2 and 1 (each within the scatter of the next).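

In this assay, changing only the stereocentre at a saturated chain carbon from R to S gives a number 64 percentage points higher from compound 3 to compound 4 (beyond the scatter), and this large gap can be assigned to configuration alone because nothing else separates the pair: the fact that compounds 3 and 4 differ only in the configuration as drawn

With the S configuration kept, swapping the group on the aromatic carbon gives a number 1 percentage points lower from compound 2 to compound 4 (within the scatter) for propyl in place of isopropyl, and a number 2 percentage points lower from compound 1 to compound 4 (within the scatter) for the added methyl that extends the chain, so compounds 1, 2 and 4 cannot be told apart in this read-out. The earlier compounds shown here left configuration and the group on the aromatic carbon tangled together, whereas this pair shows that the propyl group does not by itself bring the low number of compound 3, since compound 4 carries the same group and sits with the high numbers.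

As far as these compounds go, only the propyl compounds appear here in both configurations, so it remains open whether R forms carrying ethyl or isopropyl would also give low numbers. From the compounds shown here alone, it also remains open how a longer chain such as butyl, or an amine on that aromatic carbon, would read in either configuration.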